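This account rests on a few compounds, and the source may have more. Where it says the series, first, only, none or still open, it means among the compounds named here.

Among the compounds with values here, in a functional assay on HL-60 cells (Homo sapiens) for cytotoxicity, read by MTT assay, with a stated time of 72 h (on this read-out higher numbers stand for weaker inhibition and lower numbers for stronger inhibition), only two relatives of the compound in question have been tested so far. Compound 1 `COc1ccc(-c2c(-c3cc(Cl)c(OC)c(OC)c3)ncn2C)cc1F` gives > 10000 nM, which is a limit of the assay and not a number. Within the data shown here, compound 2 `COc1cc(-c2ncn(C)c2-c2ccc(N(C)C)cc2)cc(Cl)c1OC` gives 0.02 nM, the only true number available in this assay. Compound 2 can therefore be set only against the limit of compound 1.

The next compound, compound 3 `COc1cc(-c2ncn(C)c2-c2ccc(N(C)C)cc2)cc(Br)c1OC`, departs from compound 2 in a single place: bromo in place of chloro on an aromatic carbon. The exchanged group sits ortho to a methoxy group, and the rest of the structure stays the same.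

Among the measured compounds shown here, no measured pair shows what a single change does, so the only anchor is compound 2 at 0.02 nM. With one atom exchanged, no shift beyond the usual scatter of repeated measurements is expected, and neither direction is favoured with any confidence. The expected move is a 1.5-fold higher number from compound 2 to compound 3 (0.18 log units; within the scatter). Compound 3 is estimated at 0.03 nM, with an expected range from 0.007 nM to 0.15 nM.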

Compound 3, half-maximal inhibitory concentration: 0.2 nM
Compound 3: middle estimate off by 6.7-fold (0.82 log units), on the low side, outside the stated range (above it).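

In this assay, within the data shown here, the aromatic carbon ortho to a methoxy group is the first place where a single exchange can be read: bromo in place of chloro gives a 10-fold higher number from compound 2 to compound 3 (1.00 log units; beyond the scatter). This shows that the number at this position responds to the exchange of one halogen atom for another, even though neither group adds a ring, a hydrogen-bond donor or a hydrogen-bond acceptor, and the chloro compound has the lower number of the pair. Nothing available bears on why this exchange moves the number by this much.

Among these compounds, compound 1 gives > 10000 nM, which is a limit of the assay, and it differs from the other compounds in more than one place, so no step to it can be read. The compounds shown also leave open how a fluoro group, a methyl group, a nitrile or a plain hydrogen at this position would compare, and so whether chloro is a special case or part of a wider trend.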